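Curcumin-type chains linked to a coumarin: compound 4 expected

The source may hold more compounds than are shown below. What is called first, only, known or untested is meant among the compounds shown, and "the series" means these compounds.

The three measured compounds and their values are:

compound 1, `COc1ccc(/C=C/C(=O)/C=C/c2ccc(OCc3cn(CCCCCOc4cc(=O)oc5ccccc45)nn3)c(OC)c2)cc1`, 35%
compound 2, `COc1ccc(/C=C/C(=O)/C=C/c2ccc(OCc3cn(CCOc4cc(=O)oc5ccccc45)nn3)c(OC)c2)cc1OC`, 82%
compound 3, `COc1cc(/C=C/C(=O)/C=C/c2ccco2)ccc1OCc1cn(CCCCOc2cc(=O)oc3ccccc23)nn1`, 47%

All three were tested in a functional assay on HCT-116 cells (Homo sapiens) for inhibition, read by sulforhodamine B assay, with a stated time of 48 h, tested at 50 uM; a higher number here means more inhibition of growth at the concentration tested, a lower number less inhibition of growth. Compound 3 stands second highest of the three numbers. Its nearest neighbour is compound 1, whose value is lower by more than the usual scatter; its furthest is compound 2, whose value is higher by far more than the scatter. Nothing in these three pairs of values tells how a single change acts, since each compound differs from the others in more than one place.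

Compound 4 is `COc1ccc(/C=C/C(=O)/C=C/c2ccc(OCc3cn(CCCCOc4cc(=O)oc5ccccc45)nn3)c(OC)c2)cc1`. It differs from compound 3 in one place only: 4-methoxyphenyl in place of furan-2-yl on a double-bonded chain carbon bound to a double-bonded chain carbon. Compound 1 also carries the 4-methoxyphenyl group and gives 35%, while compound 3 with its furan-2-yl group gives 47%; the two differ by more than the scatter, but they also differ in the length of the chain to the coumarin, so the contribution of the ring alone cannot be read from them. The step of a number 2 percentage points lower from compound 3 to compound 4 (within the scatter) is therefore expected to be small, within the scatter, with no firm direction. For compound 4 the estimate in this assay is 45%, with a range from 25% to 65%.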

Compound 4, percent growth inhibition at one concentration: 40%
Estimate against measurement, compound 4: 5 percentage points above; the measured number falls inside the stated range.
By their numbers in this assay, from the lowest: compounds 1, 4 and 3 (each within the scatter of the next, the first and the last beyond it); then compound 2.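

In this assay, for the compounds shown here, this is the first pair of compounds that differ in one place only, so the ring on a double-bonded chain carbon bound to a double-bonded chain carbon can finally be judged by itself, with the chain to the coumarin held fixed. Putting 4-methoxyphenyl in place of furan-2-yl gives a number 7 percentage points lower from compound 3 to compound 4 (within the scatter), so at this chain length the test does not tell a five-membered aromatic ring with 5 heavy atoms from a six-membered aromatic ring of carbon only with 8 heavy atoms. No separate measurement is available to explain this result.

From the compounds shown here alone, it remains open whether a 4-aminophenyl or 4-carboxyphenyl group at this place would also stay within the scatter, and whether the two rings would still match with a longer chain to the coumarin. Also unresolved is the source of the high number for compound 2, 82%, as compound 2 differs from compound 4 in more than one place, leaving the separate effects of those differences unread.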